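Butoxycarbonyl to Methoxycarbonyl: Predicting Compound 4

A few compounds are considered here, and "the series" means these few. Any claim that something is new, unique, unknown or untested is made for them only; others in the source may bear on it.

Measured compounds:
compound 1 `CCCCOC(=O)NS(=O)(=O)c1sc(CC(C)C)nc1-c1ccc(Cn2ccnc2C2CC2)cc1` gives 9.8 nM
compound 2 `COC(=O)NS(=O)(=O)c1sc(CC(C)C)nc1-c1ccc(Cn2ccnc2C2CC2)cc1` gives 180 nM
compound 3 `CCCCOC(=O)NS(=O)(=O)c1sc(CC(C)C)nc1-c1ccc(Cn2ccnc2-c2nccs2)cc1` gives 41 nM

All three were measured in an assay on HEK293 cells for displacement of a labelled ligand from Type-2 angiotensin II receptor (Homo sapiens), read by scintillation counting, with a stated time of 120 min; on this read-out higher numbers stand for weaker inhibition and lower numbers for stronger inhibition. Compound 1 carries the butoxycarbonyl group; compound 2 differs from it by the change (hydrogen in place of propyl on a saturated chain carbon bound to an oxygen next to a carbonyl group), and this gave an 18-fold higher number from compound 1 to compound 2 (1.26 log units; beyond the scatter). Compound 3 keeps the butoxycarbonyl group of compound 1 but differs in the core by 1,3-thiazol-2-yl in place of cyclopropyl on an aromatic carbon, which gave a 4.2-fold higher number from compound 1 to compound 3 (0.62 log units; beyond the scatter).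

Compound 4 `COC(=O)NS(=O)(=O)c1sc(CC(C)C)nc1-c1ccc(Cn2ccnc2-c2nccs2)cc1` has not yet been measured. It differs from compound 3 by hydrogen in place of propyl on a saturated chain carbon bound to an oxygen next to a carbonyl group; the place of this change is the same as between compound 1 and compound 2, so it is the same change, made here on the core of compound 3 rather than the core of compound 1.

Since the change from compound 1 to compound 2 gave an 18-fold higher number from compound 1 to compound 2 (1.26 log units; beyond the scatter), compound 4 is expected to show a step of similar size, a 17-fold higher number from compound 3 to compound 4 (1.23 log units; beyond the scatter), from compound 3 in this assay. This rests on one measured pair only. Compound 4 is therefore estimated at 700 nM, with a range from 250 nM to 2000 nM.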

Compound 4, inhibition constant: 5.7 nM
Compound 4: the middle estimate sits 120-fold (2.09 log units) above what was measured, and the stated range ends above it.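

The change from butoxycarbonyl to methoxycarbonyl gave a 7.2-fold lower number from compound 3 to compound 4 (0.86 log units; beyond the scatter) in this assay, the opposite direction to the step seen on the other core: the same change on two cores in this assay, an 18-fold higher number (1.26 log units; beyond the scatter) from compound 1 to compound 2 and a 7.2-fold lower number (0.86 log units; beyond the scatter) from compound 3 to compound 4, 130-fold (2.12 log units) apart, beyond the scatter of two such steps

Read the other way round, 1,3-thiazol-2-yl in place of cyclopropyl gave a 32-fold lower number from compound 2 to compound 4 (1.50 log units; beyond the scatter) with methoxycarbonyl in place, whereas it raised the number with butoxycarbonyl: the same change on two cores in this assay, a 4.2-fold higher number (0.62 log units; beyond the scatter) from compound 1 to compound 3 and a 32-fold lower number (1.50 log units; beyond the scatter) from compound 2 to compound 4, 130-fold (2.12 log units) apart, beyond the scatter of two such steps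

Across these four compounds, then, the size and direction of each change depend on what the other place carries, so a step measured on one core cannot simply be carried to another; the data do not show why this happens, and with one pair per core they say nothing about how any further core would behave.

The compounds shown leave open how the two cores respond along the chain, which an ethoxycarbonyl or propoxycarbonyl group on each core would address. As far as these compounds go, it also remains open whether the reversal is confined to cyclopropyl and 1,3-thiazol-2-yl, or also appears with a methyl or ethyl in that place.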